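The source may hold more compounds than are shown below. What is called first, only, known or untested is meant among the compounds shown, and "the series" means these compounds.

Compound 1 `CCCS(=O)(=O)Nc1ccc(F)c(C(=O)c2n[nH]c3ncc(-c4ccccc4F)cc23)c1F` and compound 2 `CCCS(=O)(=O)Nc1ccc(F)c(C(=O)c2n[nH]c3ncc(-c4ccc(N(C)C)cc4)cc23)c1F` share the same core and differ only in the group attached to the outer aromatic ring. In an assay for binding affinity to dual specificity mitogen-activated protein kinase kinase 4 (Homo sapiens), read by KINOMEscan, tested at 100 nM (on this read-out higher numbers stand for a weaker effect at the one concentration tested and lower numbers for a stronger effect), compound 1 gives 2%. In this assay compound 2 gives 2.5%, and the step of a number 0.5 percentage points higher from compound 1 to compound 2 (within the scatter) shows that exchanging the whole outer group left the read-out where it was. Among the compounds with values here, of the two numbers measured so far, compound 2 has the higher one, but its gap to compound 1 lies within the scatter, so nothing separates the two compounds on this read-out. Compound 3 `CCCS(=O)(=O)Nc1ccc(F)c(C(=O)c2n[nH]c3ncc(-c4ccc(C(C)C)cc4)cc23)c1F` is the next compound. Its change from compound 2 is isopropyl in place of dimethylamino on an aromatic carbon. Within the data shown here, only one measured step bears on this change, the one from compound 1 to compound 2, and that step stayed inside the scatter even though it replaced the entire group on that ring. A smaller change on the same ring is therefore expected to give a step of a number 0.5 percentage points higher from compound 2 to compound 3 (within the scatter) that also stays within the scatter. Compound 3 is estimated at 3%, with a range from 0.5% to 12%.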

Compound 3, a percentage reported as activity, at one concentration (the size of the read-out at that concentration, not a potency): 17%
Compound 3: the middle estimate sits 14 percentage points below what was measured; measured number above the stated range.
By their numbers in this assay, from the lowest: compounds 1 and 2 (each within the scatter of the next); then compound 3.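

Changing the group on the outer ring is not always without effect in this assay: dimethylamino and isopropyl have the same count of heavy atoms, yet replacing the first with the second gives a number 14.5 percentage points higher from compound 2 to compound 3 (beyond the scatter), a weaker effect at the one concentration tested. The position para to a large group therefore responds to what is attached there, even when the swap is only carbon for nitrogen and the loss of a hydrogen-bond acceptor. The whole outer group matters too, but not in a simple way: a number 0.5 percentage points higher from compound 1 to compound 2 (within the scatter), while a number 15 percentage points higher from compound 1 to compound 3 (beyond the scatter), so 4-isopropylphenyl parts from 2-fluorophenyl where 4-(dimethylamino)phenyl does not.

From the compounds shown here alone, with only these compounds, it remains open whether the nitrogen itself or the branched carbon shape goes with the change, and a methoxy group, a tert-butyl group or a morpholine ring at the same place would help to separate those two readings. No measurement at hand explains the weaker effect of compound 3.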